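This account rests on a few compounds, and the source may have more. Where it says the series, first, only, none or still open, it means among the compounds named here.

Measured compounds
compound 1, `Cc1cccc(NC(=O)CN2CCC(c3ccc(O)cc3)CC2)c1`: in a functional assay on HEK293 cells for agonist activity at D(4) dopamine receptor (Homo sapiens), read by FLIPR (a lower number here means that less compound is needed, a higher number that more compound is needed for the effect), compound 1 gives 70 nM
compound 2, `Cc1cccc(NC(=O)CN2CCC(c3cccc(O)c3)CC2)c1`: in this assay compound 2 gives 8 nM

Among the measured compounds shown here, compound 2 holds the lowest of the two numbers; the only other point is compound 1, and the step of an 8.8-fold lower number from compound 1 to compound 2 (0.94 log units; beyond the scatter) lies beyond the scatter. That step is the sole measured one and tells only how the two hydroxyphenyl isomers differ.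

Compound 3, `Cc1cccc(NC(=O)CN2CCC(c3ccccc3F)CC2)c1`, is not yet measured. It differs from compound 2 in one place: 2-fluorophenyl in place of 3-hydroxyphenyl on a saturated ring carbon. For the measured compounds named here, no measured step removes the hydrogen-bond donor and acceptor of compound 2; the step of an 8.8-fold lower number from compound 1 to compound 2 (0.94 log units; beyond the scatter) bears on it only in showing that the aryl substitution pattern moves the number by a modest amount. With the donor and acceptor gone, a number higher than that of compound 2 is expected, but the size is uncertain and could stay within the scatter.

Compound 3 is estimated at 40 nM, range 8 nM to 250 nM, which means an expected step of a 5.0-fold higher number from compound 2 to compound 3 (0.70 log units; beyond the scatter).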

Compound 3, half-maximal effective concentration: 1 nM
For compound 3 the middle estimate is 40-fold (1.60 log units) above the measured one, and the stated range ends above it.
By their numbers in this assay, from the lowest: compound 3; then compound 2; then compound 1.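

In this assay, the hydroxyl is not required for a low number at this saturated ring carbon: the change gives an 8.0-fold lower number from compound 2 to compound 3 (0.90 log units; beyond the scatter), with 2-fluorophenyl carrying 0 hydrogen-bond donors and 0 hydrogen-bond acceptors against 1 of each in 3-hydroxyphenyl. Measured against the other isomer, the change gives a 70-fold lower number from compound 1 to compound 3 (1.85 log units; beyond the scatter), so the aryl group at this place moves the number over a wider span than the two hydroxyphenyl isomers alone showed. No supporting data are available to account for the fall in the number.

As far as these compounds go, the change alters both the substituent and its place on the phenyl ring, so the share of each remains open. From the compounds shown here alone, whether chlorine or a methoxy group on the phenyl ring would hold the number also remains open.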